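Swapping the amide partner on a shared sulfonamide core

This account rests on a few compounds, and the source may have more. Where it says the series, first, only, none or still open, it means among the compounds named here.

Measured so far:
Compound 1 `CCN(CC)S(=O)(=O)c1ccc(S(=O)(=O)N2CCC[C@@H](C(=O)N3CCC(C(F)(F)F)CC3)C2)cc1`: 110 nM
Compound 2 `CCN(CC)S(=O)(=O)c1ccc(S(=O)(=O)N2CCC[C@@H](C(=O)N[C@H]3CC[C@@H](OC)CC3)C2)cc1`: 590 nM

Going by the values given here, in a functional assay on MIA PaCa-2 cells (Homo sapiens) for inhibition, read by MTT assay, with a stated time of 3 days (on this read-out lower numbers stand for stronger inhibition and higher numbers for weaker inhibition), compound 2 gives the highest of the two numbers, with compound 1 the only neighbour. The step of a 5.4-fold higher number from compound 1 to compound 2 (0.73 log units; beyond the scatter) shows that moving from a ring-closed amide to an open amino amide raised the number. Compound 3 `CCN(CC)S(=O)(=O)c1ccc(S(=O)(=O)N2CCC[C@@H](C(=O)N3CC[C@@H](OC)C3)C2)cc1` returns to a ring-closed amide: 3-methoxypyrrolidin-1-yl in place of (4-methoxycyclohexyl)amino on a carbonyl carbon. Because a 5.4-fold higher number from compound 1 to compound 2 (0.73 log units; beyond the scatter) went up when the ring was opened, closing it again is expected to bring the number down, as a 2.4-fold lower number from compound 2 to compound 3 (0.37 log units; beyond the scatter). Compound 3 is estimated at 250 nM, within 90 nM to 700 nM.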

Compound 3, half-maximal inhibitory concentration: 1070 nM
Estimate against measurement, compound 3: 4.3-fold (0.63 log units) below; the measured number lies above the stated range.
By their numbers in this assay, from the lowest: compound 1; then compounds 2 and 3 (each within the scatter of the next).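

Closing the ring does not by itself bring the number down: the step gives a 1.8-fold higher number from compound 2 to compound 3 (0.26 log units; within the scatter), so a ring-closed amide alone does not account for the low number of compound 1. Two ring-closed partners on the carbonyl carbon can also differ clearly, as 3-methoxypyrrolidin-1-yl in place of 4-(trifluoromethyl)piperidin-1-yl gives a 9.7-fold higher number from compound 1 to compound 3 (0.99 log units; beyond the scatter). Nothing measured here explains why these amide partners differ.

Still open, going by these compounds, is how 4-methoxypiperidin-1-yl or plain piperidin-1-yl would behave at this position. Such groups would help separate the contribution of ring size from that of the trifluoromethyl group.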